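The source may report more compounds than this note shows. Statements on the series, on what has been measured and on what is new or still open speak of the compounds shown alone.

Of the compounds shown here, three of a shared core have been measured so far: compound 1 `OC1C#CCCCCC#C/C1=C\c1cccc2ccccc12`, compound 2 `OC1C#CCCCCC#C/C1=C\c1ccc2ccccc2c1` and compound 3 `COCC(=O)OC1C#CCCCCC#C/C1=C\c1ccccc1`. In a functional assay on P388 cells (Mus musculus) for inhibition, read by MTT assay (a higher number here means a weaker inhibitor, a lower number a stronger inhibitor), compound 1 gives 41000 nM, which is the highest of the three numbers, so compound 1 is the weakest inhibitor on these values. Compound 3 gives 23000 nM, and the gap between compound 3 and compound 1 lies within the usual scatter. Compound 2 gives 3600 nM, a gap from compound 1 that lies well beyond the scatter.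

Compound 4 `COCC(=O)OC1C#CCCCCC#C/C1=C\c1cccc2ccccc12` has not yet been measured. It differs from compound 1 in one place: (methoxymethyl)carbonyl in place of hydrogen on an oxygen on a saturated carbon. For the measured compounds named here, no pair of measured compounds differs by exactly this change, so no measured step guides the expectation. Compound 3 carries this same ester group on a different aromatic ring and gives 23000 nM, a number close to compound 1. Compound 4 is therefore expected to give 20000 nM in this assay, with a range from 6000 nM to 60000 nM, which means an expected step of a 2.1-fold lower number from compound 1 to compound 4 (0.31 log units; beyond the scatter) that is small and, if anything, towards a lower number.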

Compound 4, half-maximal inhibitory concentration: 12000 nM
Estimate against measurement, compound 4: 1.7-fold (0.22 log units) above, and the stated range covers the measured number.
By their numbers in this assay, from the lowest: compound 2; then compounds 4, 3 and 1 (each within the scatter of the next, the first and the last beyond it).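

For the compounds shown here, replacing the hydrogen on this oxygen with (methoxymethyl)carbonyl is the first single change that can be read directly, and in this assay it gives a 3.4-fold lower number from compound 1 to compound 4 (0.53 log units; beyond the scatter). On the core of compound 1, then, the free hydroxy group is not needed for inhibition in these cells, and this ester gives the lower number of the two. No evidence here explains why the number falls.

The compounds shown leave open whether a shorter acetyl group, a longer acyl chain or a simple methyl ether on this oxygen would give a step of similar size. They also leave open whether (methoxymethyl)carbonyl on the oxygen of compound 2 would lower the number in the same way.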